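Swapping pyridinyl for oxazolyl on a piperidine amide

The compounds below may be only part of what the source reports. "The series", "measured", "known", "first", "only" and "open" are said of these compounds alone.

Compound 1, `Cc1ccc(NC(=O)c2cccc(C(F)(F)F)c2)cc1OC1CCN(C(=O)c2cccnc2)CC1`, in an ADME assay on BaF3 cells (Mus musculus) for antiproliferative activity (on this read-out lower numbers stand for stronger inhibition of growth and higher numbers for weaker inhibition of growth), gives > 10000 nM, which is a limit of the assay and not a number.
Compound 2, `Cc1ccc(NC(=O)c2cccc(C(F)(F)F)c2)cc1OC1CCN(C(=O)c2ccno2)CC1`, in this assay gives > 10000 nM, also a limit.
Compound 3, `O=C(Nc1cccc(OC2CCCN(C(=O)c3cccnc3)C2)c1)c1cccc(C(F)(F)F)c1`, in this assay gives 8070 nM.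

The change from compound 1 to compound 2 is 1,2-oxazol-5-yl in place of pyridin-3-yl on a carbonyl carbon; its step is a step that the two limits leave unreadable from compound 1 to compound 2. The cores of compound 1 and compound 3 differ in a way that is not broken down here. Compound 4, `O=C(Nc1cccc(OC2CCCN(C(=O)c3ccno3)C2)c1)c1cccc(C(F)(F)F)c1`, carries the same change relative to compound 3: 1,2-oxazol-5-yl in place of pyridin-3-yl on a carbonyl carbon. The expectation for compound 4 rests on compound 3, which gives 8070 nM. The step of a 1.1-fold higher number from compound 3 to compound 4 (0.05 log units; within the scatter) is expected to be small because of the limit of > 10000 nM in this assay, at which 2 of the 3 values shown sit. Compound 4 is estimated at 9000 nM, between 3000 nM and 30000 nM.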

Compound 4, concentration for 50% growth inhibition: > 10000 nM
Compound 4: only a limit was reported (the forecaster's own chance of this, stated with the estimate: 50%); middle value at least 1.1-fold (0.04 log units) away from the limit.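

In this assay compound 4 gives > 10000 nM, which is a limit of the assay and not a number. Going by these compounds, replacing pyridin-3-yl with 1,2-oxazol-5-yl on the carbonyl carbon gives an at least 1.2-fold higher number from compound 3 to compound 4 (0.09 log units; that floor lies within the scatter), so only a floor for this step is known, and its true size remains unknown. The same change on the core of compound 1 cannot be read, so whether it carries over from one core to the other is neither confirmed nor ruled out, because so many values sit at one limit: the limit of > 10000 nM in this assay, at which 3 of the 4 values shown sit.

Among these compounds, only compound 3 gives a number, 8070 nM. On these data alone, it remains open whether another group on the carbonyl carbon, such as an amine-bearing chain or a carboxylic acid, would give a value clear of the limit.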